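A few compounds are considered here, and "the series" means these few. Any claim that something is new, unique, unknown or untested is made for them only; others in the source may bear on it.

In a functional assay on MIA PaCa-2 cells (Homo sapiens) for inhibition, read by MTT assay, with a stated time of 48 h, tested at 10 uM (on this read-out higher numbers stand for more inhibition of growth at the one concentration tested and lower numbers for less inhibition of growth), compound 1 `Cc1cc(=O)c2c(O)cc(OC/C=C/c3ccccc3)c([C@H]3CCN(C)C[C@H]3O)c2o1` gives 11%, compound 2 `Cc1cc(=O)c2c(O)c(CN3CCN(C(=O)OC(C)(C)C)CC3)c(O)c([C@H]3CCN(C)C[C@H]3O)c2o1` gives 6% and compound 3 `Cc1oc2c([C@H]3CCN(C)C[C@H]3O)c(O)cc(O)c2c(=O)c1C(O)c1ccc([N+](=O)[O-])cc1` gives 2%. Compound 3 therefore stands within the usual scatter of both other compounds, and the three numbers cannot be told apart. Compound 4 `COc1ccc(C(O)c2c(C)oc3c([C@H]4CCN(C)C[C@H]4O)c(O)cc(O)c3c2=O)cc1Br` has not yet been measured. It keeps the core of compound 3 and differs in one place: 3-bromo-4-methoxyphenyl in place of 4-nitrophenyl on a saturated chain carbon bound to an aromatic carbon and an oxygen on a saturated carbon. Going by the values given here, no two measured compounds differ in only one place, so no measured step can guide this comparison. Any shift in this assay is therefore expected to stay within the scatter, with no firm direction. The estimated change is a number 4 percentage points higher from compound 3 to compound 4 (within the scatter). For compound 4 the expected value is 6%, with an estimated range from 0% to 20%.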

Compound 4, percent growth inhibition at one concentration: 3%
Compound 4: the middle estimate sits 3 percentage points above what was measured, and the stated range covers the measured number.
By their numbers in this assay, from the lowest: compounds 3, 4, 2 and 1 (each within the scatter of the next).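

In this assay, going by these compounds alone, 3-bromo-4-methoxyphenyl in place of 4-nitrophenyl gives a number 1 percentage points higher from compound 3 to compound 4 (within the scatter), the first comparison here between compounds that differ in one place. At this position, then, these two quite different aromatic groups cannot be told apart on this read-out. No supporting measurement bears on this result.

As far as these compounds go, whether an aminomethyl group or a carboxylic acid on the phenyl ring would give a different reading stays open. So does the effect of a longer chain between the hydroxyl-bearing carbon and the ring.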